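Shortening the alkynyl chain on a shared core

The source may hold more compounds than are shown below. What is called first, only, known or untested is meant among the compounds shown, and "the series" means these compounds.

Three compounds built on the same core have been examined in a functional assay on L1210 cells (Mus musculus); a lower number here means a stronger inhibitor, a higher number a weaker inhibitor. For the measured compounds named here, compound 2 `CCCCCC#Cc1cn([C@H]2C[C@H](O)[C@@H](CO)O2)c(=O)[nH]c1=O` is the only one that yields a number: in this assay compound 2 gives 219 ug/mL. Compound 1 `CCC#Cc1cn(C2O[C@H](CO)[C@@H](O)[C@@H]2O)c(=O)[nH]c1=O` reaches only a limit in this assay, > 1000 ug/mL. Compound 3 `Cc1ccc(S(=O)(=O)OCCC#Cc2cn([C@H]3C[C@H](O)[C@@H](CO)O3)c(=O)[nH]c2=O)cc1` likewise stops at a limit in this assay, > 200 ug/mL. Going by the values given here, compound 2 therefore stands alone as the single measured value, while the other two sit at limits, as recorded in the limit of > 1000 ug/mL in this assay, at which 1 of the 3 values shown sits, and (the limit of > 200 ug/mL in this assay, at which 1 of the 3 values shown sits).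

The unmeasured compound 4 `CCCC#Cc1cn([C@H]2C[C@H](O)[C@@H](CO)O2)c(=O)[nH]c1=O` differs from compound 2 in one place: hydrogen in place of ethyl on a saturated chain carbon, three bonds along the chain from a triple-bonded carbon. Among the compounds with values here, no step between two measured compounds is available, so the size of this change cannot be read from any measured pair. Compound 1 and compound 3 each differ from compound 2 in more than one place, and their limits cannot be set against the number of compound 2. The writer expects the shorter chain of compound 4 to weaken inhibition in this assay, with a step of a 2.7-fold higher number from compound 2 to compound 4 (0.44 log units; beyond the scatter) expected, and a real chance that only a limit is reported. The estimate for compound 4 in this assay is 600 ug/mL, within a range from 150 ug/mL to 3000 ug/mL.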

Compound 4, concentration for 50% inhibition: > 1000 ug/mL
Compound 4: a limit, no number; the forecaster's own chance of this, stated with the estimate: 50%; middle value at least 1.6-fold (0.22 log units) away from the limit.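

In this assay, for the compounds shown here, hydrogen in place of ethyl on a saturated chain carbon, three bonds along the chain from a triple-bonded carbon, gives an at least 4.5-fold higher number from compound 2 to compound 4 (0.65 log units; beyond the scatter) and is the first step on the shared core that can be read. This shows that the outer ethyl of the pentyl chain of compound 2 counts at this position, since the propyl chain of compound 4 no longer yields a number. Compound 4 gives only a limit, > 1000 ug/mL, so the step has a lower bound and its full size is unknown, and this limit is a common one among the compounds shown: the limit of > 1000 ug/mL in this assay, at which 2 of the 4 values shown sit.

On these data alone, whether a butyl chain would give a number between these two, and whether a longer chain such as hexyl or octyl, or an amine or carboxylic acid at the chain end, would lower the number further remains open. Steps involving compound 1 and compound 3 cannot be read, so the chain trend rests on the single pair of compound 2 and compound 4.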